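Dropping a Methoxy Group from a Kinase Inhibitor

The source may report more compounds than this note shows. Statements on the series, on what has been measured and on what is new or still open speak of the compounds shown alone.

Two compounds measured so far:
compound 1 `COC(=O)c1cccc(-c2cnc3[nH]cc(-c4cccc(OC)c4)c3c2)c1` gives 166 nM
compound 2 `N#Cc1cccc(-c2cnc3[nH]cc(-c4cccnc4)c3c2)c1` gives 129 nM

Both numbers come from an assay on isolated protein for inhibition of serine/threonine-protein kinase Nek1 (Homo sapiens), read by radiometric assay and 33P incorporation, in the presence of a further agent that is not named here; on this read-out lower numbers stand for stronger inhibition and higher numbers for weaker inhibition. In this assay compound 1 and compound 2 sit within the usual scatter of each other, so neither stands apart. Compound 3 `COC(=O)c1cccc(-c2cnc3[nH]cc(-c4ccccc4)c3c2)c1` has not been measured yet. It differs from compound 1 in one place: hydrogen in place of methoxy on an aromatic carbon. For the measured compounds named here, no step between two measured compounds is available to guide this change, so the expected step of a 1.3-fold higher number from compound 1 to compound 3 (0.12 log units; within the scatter) is small, leaning towards a somewhat higher number, and may well stay within the scatter. Compound 3 is therefore estimated at 220 nM, with a range from 90 nM to 550 nM.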

Compound 3, half-maximal inhibitory concentration: 123 nM
Compound 3: middle estimate off by 1.8-fold (0.25 log units), on the high side; the range from low to high includes it.
By their numbers in this assay, from the lowest: compounds 3, 2 and 1 (each within the scatter of the next).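

In this assay, the change from 3-methoxyphenyl to phenyl gives a 1.3-fold lower number from compound 1 to compound 3 (0.13 log units; within the scatter). The methoxy group at this place on the ring can therefore go, with its two heavy atoms and its hydrogen-bond acceptor, and inhibition of the kinase stays within the scatter. Nothing measured here offers an explanation for this result. On these data alone, whether an amine, a carboxylic acid or a longer chain at this place would shift the number beyond the scatter remains open. So does whether the same change would read alike with a nitrile in place of the methyl ester.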